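Working notes on the step from compound 3 to compound 4

A few compounds are considered here, and "the series" means these few. Any claim that something is new, unique, unknown or untested is made for them only; others in the source may bear on it.

Compound 1 `Nc1nc(-c2ccccc2)nn1-c1ncnc2cc(Cl)ccc12`: in an assay on MCF7 cells for inhibition of Serine-protein kinase ATM (Homo sapiens), read by immunofluorescence, with a stated time of 1 h (a higher number here means a weaker inhibitor, a lower number a stronger inhibitor), compound 1 gives > 40000 nM, which is a limit of the assay rather than a number.
Compound 2 `COc1cc2ncnc(-n3nc(-c4ccccn4)cc3N)c2cc1OC`: compound 2 gives 1600 nM.
Compound 3 `COc1cc2ncnc(-n3nc(-c4ccccc4)cc3N)c2cc1OC`: compound 3 gives 20600 nM.

Within the data shown here, compound 3 stands with the highest of the two numbers, the only measured step being a 13-fold higher number from compound 2 to compound 3 (1.11 log units; beyond the scatter). Compound 4 `COc1cc2ncnc(-n3nc(-c4ccc(C)cc4)cc3N)c2cc1OC` differs from compound 3 by methyl in place of hydrogen on an aromatic carbon. Among the measured compounds shown here, no measured step touches this change; the one step measured, from a pyridin-2-yl to a phenyl, concerns a different part of the ring, so it gives no bearing on a methyl. The expectation for a 1.0-fold lower number from compound 3 to compound 4 (0.01 log units; within the scatter) is therefore no step beyond the scatter. Compound 4 is estimated at 20000 nM, expected within 7000 nM to 60000 nM.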

Compound 4, half-maximal inhibitory concentration: > 40000 nM
Compound 4 was reported as a limit; the forecaster's own chance of this, stated with the estimate: 25%; at least 2.0-fold (0.30 log units) between middle value and limit.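

Compound 4 is reported only as a limit of the assay, not a number: the limit of > 40000 nM in this assay, at which 2 of the 4 values shown sit.

On the phenyl, para to a large group, methyl brings no gain in strength, with an at least 1.9-fold higher number from compound 3 to compound 4 (0.28 log units; that floor lies within the scatter), so the true size of this change remains unread. The pyridin-2-yl comparison still holds, with an at least 25-fold higher number from compound 2 to compound 4 (1.39 log units; beyond the scatter), so this methyl does not recover what the phenyl gives up.

Open, on these data alone, is whether an amine or a carboxylic acid at this place would move the number on the phenyl. Also open, as far as these compounds go, is whether the pyridin-2-yl of compound 2, at 1600 nM, tolerates a methyl there.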